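A Longer Chain on a Compound at the Limit

A few compounds are considered here, and "the series" means these few. Any claim that something is new, unique, unknown or untested is made for them only; others in the source may bear on it.

Compound 1 `O=C1NCCN1c1ccc(S(=O)(=O)Nc2ccc(F)cc2)cc1`: 690 nM
Compound 2 `CCc1ccc(NS(=O)(=O)c2ccc(N3CCNC3=O)cc2)cc1`: 810 nM
Compound 3 `CC(C)Cc1ccc(NS(=O)(=O)c2ccc(N3CCNC3=O)cc2)cc1`: > 1000 nM (a limit, not a number)

These results come from a functional assay on MCF7 cells (Homo sapiens) for antiproliferative activity, read by sulforhodamine B assay, with a stated time of 48 h; on this read-out lower numbers stand for stronger inhibition and higher numbers for weaker inhibition. Going by these compounds, compound 3 gives only a limit, > 1000 nM, so its true value is unknown. Compound 3 thus sits at the limit of > 1000 nM in this assay, at which 1 of the 3 values shown sits.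

Compound 4 `CCCCCc1ccc(NS(=O)(=O)c2ccc(N3CCNC3=O)cc2)cc1` has butyl in place of isopropyl on a saturated chain carbon bound to an aromatic carbon. The same difference, cut one bond further out, reads isobutyl to pentyl.

Three measured steps change this same group. Ethyl in place of fluoro gave a 1.2-fold higher number from compound 1 to compound 2 (0.07 log units; within the scatter). Isobutyl in place of fluoro gave an at least 1.4-fold higher number from compound 1 to compound 3 (0.16 log units; that floor lies within the scatter). Isopropyl in place of methyl gave an at least 1.2-fold higher number from compound 2 to compound 3 (0.09 log units; that floor lies within the scatter). None of these steps is shown to exceed the scatter, and the two that reach compound 3 are only floors.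

No step beyond the scatter is therefore expected, and the estimated step is a step that the limit leaves unreadable from compound 3 to compound 4. For compound 4 the estimate is 1400 nM. The expected range for compound 4 runs from 700 nM to 4000 nM.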

Compound 4, half-maximal inhibitory concentration: > 1000 nM
Compound 4: no number, only a limit; the forecaster's own chance of this, stated with the estimate: 65%; the middle value does not contradict the limit.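

In this assay compound 4 gives > 1000 nM, which is a limit and not a number, and it is the same limit that compound 3 reached: the limit of > 1000 nM in this assay, at which 2 of the 4 values shown sit. The step from compound 3 to compound 4 cannot be read, so nothing can be said about butyl in place of isopropyl at this place. The pentyl chain of compound 4 gives an at least 1.2-fold higher number from compound 2 to compound 4 (0.09 log units; that floor lies within the scatter) and an at least 1.4-fold higher number from compound 1 to compound 4 (0.16 log units; that floor lies within the scatter), so even this longer chain is not shown to differ from ethyl or fluoro.

Going by these compounds, how far compound 3 and compound 4 truly lie from compound 1 and compound 2 stays open. The compounds shown also leave open how an amine or a carboxylic acid in this place would read in this assay.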